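From 2,6-dimethylphenyl to 3,5-dimethylphenyl

The source may hold more compounds than are shown below. What is called first, only, known or untested is meant among the compounds shown, and "the series" means these compounds.

In a functional assay on HCT-8 cells (Homo sapiens) for cytotoxicity (a lower number here means that less compound is needed, a higher number that more compound is needed for the effect), compound 1 `CCc1ccc(/C=C/C(O)=C2/C(=O)C(C)=C(OC)C(C)(C)C2=O)cc1` gives 10.5 ug/mL and compound 2 `COC1=C(C)C(=O)/C(=C(O)/C=C/c2c(C)cccc2C)C(=O)C1(C)C` gives 7.8 ug/mL. Among the compounds with values here, the single measured step, a 1.3-fold lower number from compound 1 to compound 2 (0.13 log units; within the scatter), lies within the scatter, so compound 2 stands level with compound 1. Compound 3 `COC1=C(C)C(=O)/C(=C(O)/C=C/c2cc(C)cc(C)c2)C(=O)C1(C)C` carries 3,5-dimethylphenyl in place of 2,6-dimethylphenyl on a double-bonded chain carbon bound to a double-bonded chain carbon. Within the data shown here, only that step bears on this change, and it gives no ground to expect a shift beyond the scatter. The expected change is small, an estimated 1.2-fold higher number from compound 2 to compound 3 (0.06 log units; within the scatter). For compound 3 the estimate is 9 ug/mL, with an expected range of 4.5 ug/mL to 18 ug/mL.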

Compound 3, concentration for half-maximal effect: 2.9 ug/mL
For compound 3 the middle estimate is 3.1-fold (0.49 log units) above the measured one; the whole stated range lies above it.
By their numbers in this assay, from the lowest: compound 3; then compounds 2 and 1 (each within the scatter of the next).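

In this assay, within the data shown here, rearranging the methyl groups from 2,6-dimethylphenyl to 3,5-dimethylphenyl gives a 2.7-fold lower number from compound 2 to compound 3 (0.43 log units; beyond the scatter), the first step beyond the scatter, and the swap from 4-ethylphenyl gives a 3.6-fold lower number from compound 1 to compound 3 (0.56 log units; beyond the scatter) as well. This place on the double-bonded chain carbon therefore responds to the arrangement of the methyl groups, even though the leaving and entering groups have the same counts. Nothing available explains this difference.

On these data alone, how a phenyl ring bearing an amine or a carboxylic acid would read at this place remains open. So does whether 3,5-dimethoxyphenyl would match 3,5-dimethylphenyl.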